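Arylpyridazinone amides in the cytotoxicity assay: compound 3 to compound 4

The compounds below may be only part of what the source reports. "The series", "measured", "known", "first", "only" and "open" are said of these compounds alone.

Measured compounds:
- compound 1 `Cn1ccc2c(Oc3ccc(NC(=O)c4nn(-c5ccc(Br)cc5F)ccc4=O)cc3)ccnc21`: 35700 nM
- compound 2 `COc1ccc(-n2ccc(=O)c(C(=O)Nc3ccc(Oc4ccnc5c4ccn5C)c(F)c3)n2)cc1`: > 60000 nM
- compound 3 `Cn1ccc2c(Oc3ccc(NC(=O)c4nn(-c5ccccc5)ccc4=O)cc3F)ccnc21`: > 60000 nM

In a functional assay on A549 cells (Homo sapiens) for cytotoxicity, read by MTT assay, with a stated time of 72 h (on this read-out higher numbers stand for weaker inhibition and lower numbers for stronger inhibition), compound 3 returns only a limit, > 60000 nM. Compound 2 likewise returns only a limit, > 60000 nM. Among the measured compounds shown here, the single readable pair, a step that the two limits leave unreadable from compound 2 to compound 3, therefore gives no usable size, as both values sit at the limit of > 60000 nM in this assay, at which 2 of the 3 values shown sit. Compound 1, in this assay, gives 35700 nM, a number rather than a limit.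

Compound 4 `Cn1ccc2c(Oc3ccc(NC(=O)c4nn(-c5ccc(Br)cc5F)ccc4=O)cc3F)ccnc21` is not yet measured. It differs from compound 3 by 4-bromo-2-fluorophenyl in place of phenyl on an aromatic nitrogen. For the measured compounds named here, no measured step covers this exact change, and compound 1 differs from compound 4 in a second place, so its value can only be noted, not turned into a step. Given that compound 1 carries the same 4-bromo-2-fluorophenyl group and gives 35700 nM, compound 4 is expected to land in a similar weak range, which would mean a step of an at least 1.2-fold lower number from compound 3 to compound 4 (0.07 log units; that floor lies within the scatter) that is not readable against the scatter. Compound 4 is thus estimated at 50000 nM, with a range of 20000 nM to 150000 nM, and a fair chance that this assay again reports only a limit.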

Compound 4, half-maximal inhibitory concentration: 26800 nM
Compound 4: the middle estimate sits 1.9-fold (0.27 log units) above what was measured; the measured number falls inside the stated range.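

In this assay, among the compounds shown here, 4-bromo-2-fluorophenyl in place of phenyl on an aromatic nitrogen gives an at least 2.2-fold lower number from compound 3 to compound 4 (0.35 log units; beyond the scatter), and in place of 4-methoxyphenyl it gives an at least 2.2-fold lower number from compound 2 to compound 4 (0.35 log units; beyond the scatter), so this position now shows steps beyond the scatter, which the earlier compounds could not show. Fluoro in place of hydrogen on an aromatic carbon, with 4-bromo-2-fluorophenyl held fixed, gives a 1.3-fold lower number from compound 1 to compound 4 (0.12 log units; within the scatter), so that change has no readable effect here. The two steps beyond the scatter are floors rather than full sizes, as each starts from a limit: the limit of > 60000 nM in this assay, at which 2 of the 4 values shown sit.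

Still open, as far as these compounds go, is whether the bromo, the fluoro or the two together carry the step at the aromatic nitrogen. Also open, from the compounds shown here alone, is how an amine or a carboxylic acid in the place of the bromo would read in this assay.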